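The source may hold more compounds than are shown below. What is called first, only, known or untested is meant among the compounds shown, and "the series" means these compounds.

Compound 1 `Cc1ccc(S(=O)(=O)c2cnc3ccc(Cl)cc3c2N2CCC(C)CC2)cc1F` gives 68% in an assay on isolated protein for displacement of a labelled ligand from metabotropic glutamate receptor 5 (Homo sapiens), with a stated time of 60 min, tested at 1 uM (on this read-out higher numbers stand for more inhibition at the one concentration tested (going by the name of the read-out) and lower numbers for less inhibition), the lowest of the three numbers shown. Compound 2 `COc1ccc2ncc(S(=O)(=O)c3ccc(C)c(F)c3)c(N3CCC(C)CC3)c2c1` gives 73%, and compound 3 `Cc1ccc2ncc(S(=O)(=O)c3ccc(C)c(F)c3)c(N3CCC(C)CC3)c2c1` gives 91%. The measured steps, a number 5 percentage points higher from compound 1 to compound 2 (within the scatter), a number 23 percentage points higher from compound 1 to compound 3 (beyond the scatter) and a number 18 percentage points higher from compound 2 to compound 3 (beyond the scatter), all arise from exchanges on an aromatic carbon of the shared core. Compound 4 `CC1CCN(c2c(S(=O)(=O)c3ccc(C#N)cc3)cnc3ccc(Cl)cc23)CC1` differs from compound 1 at a different place: 4-cyanophenyl in place of 3-fluoro-4-methylphenyl on a sulfonyl sulfur. Going by the values given here, none of the measured steps alters the group on the sulfonyl sulfur, so there is no measured change that bears directly on this exchange. What is expected is a number 8 percentage points lower from compound 1 to compound 4 (within the scatter), with little confidence in either size or direction. Compound 4 is estimated at 60%, within a range from 35% to 85%.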

Compound 4, a percentage reported as inhibition, at one concentration (the size of the read-out at that concentration, not a potency): 31%
Compound 4: middle estimate off by 29 percentage points, on the high side, outside the stated range (below it).
By their numbers in this assay, from the lowest: compound 4; then compounds 1 and 2 (each within the scatter of the next); then compound 3.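

In this assay, the group on the sulfonyl sulfur proves to matter: 4-cyanophenyl in place of 3-fluoro-4-methylphenyl gives a number 37 percentage points lower from compound 1 to compound 4 (beyond the scatter). This large step exceeds the modest steps seen for exchanges on an aromatic carbon of the shared core. Nothing at hand explains the step.

The compounds shown leave open whether the nitrile or the loss of the 3-fluoro-4-methylphenyl group carries this step, and how a plain phenyl or 4-methylphenyl on the sulfonyl sulfur would read. On these data alone, whether the same exchange would give a similar step on the core of compound 3 also remains open.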